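The source may hold more compounds than are shown below. What is called first, only, known or untested is meant among the compounds shown, and "the series" means these compounds.

Compound 1 `c1ccc(Oc2ccc3c(NCCCNCc4ccco4)ccnc3c2)cc1` gives 317 10^-6 cm/s in an ADME assay for permeability, using PAMPA, with a stated time of 30 min, at pH 7.4; a lower number here means that the compound crosses the layer more slowly, a higher number that the compound crosses the layer faster. Compound 2 `COc1cccc(CNCCCNc2ccnc3cc(Oc4ccccc4)ccc23)c1O` gives 317 10^-6 cm/s in this assay, level with compound 1 at the digits shown, and together the two sit at the top of the three numbers. Compound 3 `COc1ccc(F)cc1CNCCCNc1ccnc2cc(-c3ccc(F)cc3)ccc12` gives 237 10^-6 cm/s in this assay, a gap from compound 1 that lies within the scatter. no change at the digits printed from compound 1 to compound 2 (within the scatter): 2-hydroxy-3-methoxyphenyl in place of furan-2-yl on a saturated chain carbon bound to an amine nitrogen left the number where it was.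

Compound 4 `COc1cccc(Oc2ccc3c(NCCCNCc4ccco4)ccnc3c2)c1` differs from compound 1 as follows: methoxy in place of hydrogen on an aromatic carbon. Hydrogen leaves and methoxy enters on an aromatic carbon of a six-membered aromatic ring of carbon only, meta to a large group, so phenoxy becomes 3-methoxyphenoxy. Among the measured compounds shown here, no measured step covers this exact change; the nearest precedent is the step from compound 1 to compound 2, where a larger swap elsewhere moved nothing, and the whole spread over the three compounds stays within the scatter. Compound 4 is thus expected to show a 1.1-fold lower number from compound 1 to compound 4 (0.02 log units; within the scatter), nothing beyond the scatter. Compound 4 is estimated to give 300 10^-6 cm/s in this assay, within the range 190 10^-6 cm/s to 450 10^-6 cm/s.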

Compound 4, apparent permeability: 317 10^-6 cm/s
Beside the measured number, compound 4's estimate is 1.1-fold (0.02 log units) below it, within the range that was stated.
By their numbers in this assay, from the lowest: compounds 3, 1, 2 and 4 (each within the scatter of the next).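

In this assay, the change of phenoxy to 3-methoxyphenoxy, with methoxy in place of hydrogen on an aromatic carbon, gives no change at the digits printed from compound 1 to compound 4 (within the scatter). The earlier step changed the furan-2-yl end of the molecule, whereas this one changes the phenoxy group, so changes in two different places on compound 1 now read the same way, with no compound shown going against this. No supporting measurement accompanies these numbers to account for the result.

The compounds shown leave open whether an amine or a carboxylic acid on this same aromatic carbon would leave the number in place. They also leave open whether a longer chain in place of the saturated chain of compound 1 would do the same.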